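The compounds below may be only part of what the source reports. "The series", "measured", "known", "first", "only" and "open" are said of these compounds alone.

In a functional assay on MGC-803 cells (Homo sapiens) for antiproliferative activity, read by CellTiter-Glo, with a stated time of 72 h (on this read-out lower numbers stand for stronger inhibition and higher numbers for weaker inhibition), three compounds of the series have been measured. Compound 1 (`O=C(NO)c1ccc(/C=C/c2ccnc(-c3ccc(F)cc3)c2)cc1`) gives > 10000 nM, which is a limit of the assay and not a number. Compound 2 (`COc1ccc(-c2cc(/C=C/c3ccc(C(=O)NO)cc3)ccn2)cc1`) gives 3510 nM. Compound 3 (`O=C(NO)c1ccc(/C=C/c2cccc(-c3cccc(O)c3)c2)cc1`) gives 8820 nM, the higher of the two actual numbers and higher than that of compound 2.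

Compound 4 (`O=C(NO)c1ccc(/C=C/c2cccc(-c3cc(F)ccc3O)c2)cc1`) has 5-fluoro-2-hydroxyphenyl in place of the 3-hydroxyphenyl of compound 3 on an aromatic carbon: 5-fluoro-2-hydroxyphenyl in place of 3-hydroxyphenyl on an aromatic carbon.

Among the compounds with values here, the only measured step involving fluoro is an at least 2.8-fold lower number from compound 1 to compound 2 (0.45 log units; beyond the scatter), with methoxy in place of fluoro on an aromatic carbon. It is a weak guide: it belongs to the core of compound 1, not that of compound 3, and one end of it is the limit of > 10000 nM in this assay, at which 1 of the 3 values shown sits. Within the data shown here, no measured step covers the present exchange directly, so no step beyond the scatter is expected in this assay, and no direction is favoured.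

The expected change is a 1.2-fold lower number from compound 3 to compound 4 (0.07 log units; within the scatter). For compound 4 the estimated value is 7500 nM, with an expected range of 3000 nM to 15000 nM.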

Compound 4, half-maximal inhibitory concentration: > 10000 nM
Compound 4: no number, only a limit (the forecaster's own chance of this, stated with the estimate: 30%); middle value at least 1.3-fold (0.12 log units) away from the limit.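

In this assay compound 4 gives > 10000 nM, which is a limit of the assay and not a number. Replacing 3-hydroxyphenyl with 5-fluoro-2-hydroxyphenyl on an aromatic carbon, meta to a large group, gives an at least 1.1-fold higher number from compound 3 to compound 4 (0.05 log units; that floor lies within the scatter), so this exchange brings no lower number at this position, while a real loss is neither shown nor excluded. The result also leaves less of the series resolved as numbers: the limit of > 10000 nM in this assay, at which 2 of the 4 values shown sit.

The exchange alters the hydroxyphenyl group and adds fluoro in a single step, and the compounds shown do not separate these two changes. On these data alone, whether an amine or a carboxylic acid in place of the hydroxy group on this ring would give a number clear of the limit also remains open.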